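Compound 1 to compound 4: one added hydroxy

The source may hold more compounds than are shown below. What is called first, only, known or untested is meant among the compounds shown, and "the series" means these compounds.

In a functional assay on Gurav cells (Homo sapiens) for inhibition, read by sulforhodamine B assay (on this read-out lower numbers stand for stronger inhibition of growth and higher numbers for weaker inhibition of growth), compound 1 (`Oc1ccc(-c2ccc(-c3ccc(-c4nc5ccccc5[nH]4)cc3)cc2)cc1`) reads 100000 nM and compound 3 (`CN(C)c1ccc(-c2ccc(-c3ccc(-c4nc5ccccc5[nH]4)cc3)cc2)cc1`) reads 100000 nM as the highest of the three numbers, while compound 2 (`COc1ccc(-c2ccc(-c3ccc(-c4nc5ccccc5[nH]4)cc3)cc2)cc1`) reads 38100 nM as the lowest.

Compound 4 (`Oc1ccc(-c2ccc(-c3ccc(-c4nc5c(O)cccc5[nH]4)cc3)cc2)cc1`) differs from compound 1 by hydroxy in place of hydrogen on an aromatic carbon of a six-membered aromatic ring of carbon only, part of a fused or bridged system of two rings (hydroxy in place of hydrogen on an aromatic carbon).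

Among the compounds with values here, no measured step touches that place, so the three steps bear on it only indirectly. The step of a 2.6-fold lower number from compound 1 to compound 2 (0.42 log units; beyond the scatter) and the step of a 2.6-fold higher number from compound 2 to compound 3 (0.42 log units; beyond the scatter) are modest, and the step of no change at the digits printed from compound 1 to compound 3 (within the scatter) stays within the scatter. Within the data shown here, no compound measured so far carries the new hydroxy.

A large change in this assay is therefore not expected. The expected step of a 1.4-fold lower number from compound 1 to compound 4 (0.15 log units; within the scatter) stays small, with only a weak lean toward a lower number. Compound 4 is estimated at 70000 nM (expected range 25000 nM to 150000 nM).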

Compound 4, concentration for 50% growth inhibition: 190 nM
Estimate against measurement, compound 4: 370-fold (2.57 log units) above; measured number outside the range, below it.
By their numbers in this assay, from the lowest: compound 4; then compound 2; then compounds 1 and 3 (each within the scatter of the next).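

In this assay, within the data shown here, hydroxy in place of hydrogen on an aromatic carbon of the six-membered aromatic ring of carbon only, part of a fused or bridged system of two rings, gives a 530-fold lower number from compound 1 to compound 4 (2.72 log units; beyond the scatter) and is the first large step. This place therefore weighs far more on growth inhibition than the earlier change of the existing hydroxy to methoxy, which gave only a 2.6-fold lower number from compound 1 to compound 2 (0.42 log units; beyond the scatter) and leaves compound 4 with the lowest number of the four compounds. No measurement shown accounts for the size of this step.

Still open, as far as these compounds go, is whether the gain is specific to hydroxy, or whether methoxy, an amine or a carboxylic acid at the same place would give a similar step. From the compounds shown here alone, it is also open whether the gain would persist with methoxy or dimethylamino in place of the other hydroxy of compound 4.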